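A few compounds are considered here, and "the series" means these few. Any claim that something is new, unique, unknown or untested is made for them only; others in the source may bear on it.

Compound 2 `CC1=CC[C@@H]([C@@](C)(O)CCCC(C)(C)NC(=S)N/N=C\c2ccccc2)CC1` was tested in a functional assay on UACC-62 cells (Homo sapiens) for cytotoxicity, read by sulforhodamine B assay (a higher number here means a weaker inhibitor of growth, a lower number a stronger inhibitor of growth), where it gives 43800 nM. Its number sits level with that of compound 1 `CC1=CC[C@@H]([C@@](C)(O)CCCC(C)(C)NC=S)CC1`, which in this assay gives 42500 nM; the step of a 1.0-fold higher number from compound 1 to compound 2 (0.01 log units; within the scatter) shows that the large addition on the thiocarbonyl carbon changed nothing that can be trusted. Compound 3 `CC1=CC[C@@H]([C@@](C)(O)CCCC(C)(C)NC(=S)N/N=C\c2ccc(N(C)C)cc2)CC1` returned only a limit in this assay, > 100000 nM. The step of an at least 2.2-fold higher number from compound 2 to compound 3 (0.35 log units; beyond the scatter) is read against that limit of > 100000 nM in this assay, at which 1 of the 3 values shown sits: dimethylamino in place of hydrogen on an aromatic carbon weakened growth inhibition at least modestly.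

Compound 4 `CC1=CC[C@@H]([C@@](C)(O)CCCC(C)(C)NC(=S)N/N=C\c2ccccc2[N+](=O)[O-])CC1` differs from compound 2 in one place: nitro in place of hydrogen on an aromatic carbon. Among the compounds with values here, only one measured step concerns a substituent on this aromatic ring, the step from compound 2 to compound 3, and it went toward a weaker inhibitor. Within the data shown here, a nitro group is not a dimethylamino group, so that step is loose guidance, and no nitro analogue has been measured here. The expectation is a small move toward a higher number, a 1.4-fold higher number from compound 2 to compound 4 (0.14 log units; within the scatter), with a fair chance that the change stays within the scatter. Compound 4 is therefore estimated at 60000 nM, with a likely range from 28000 nM to 130000 nM.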

Compound 4, concentration for total growth inhibition: 16600 nM
For compound 4 the middle estimate is 3.6-fold (0.56 log units) above the measured one, outside the stated range (below it).
By their numbers in this assay, from the lowest: compound 4; then compounds 1 and 2 (each within the scatter of the next). At a limit, above all of these: compound 3.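

With a 2.6-fold lower number from compound 2 to compound 4 (0.42 log units; beyond the scatter), the change from phenyl to 2-nitrophenyl is the only single change shown on this aromatic ring that moves toward stronger growth inhibition in this assay. The ring is therefore not a place where every added group costs activity, as the dimethylamino group of compound 3 alone might have suggested, and a group placed ortho to the large group can improve on the bare phenyl ring of compound 2. The wider step an at least 6.0-fold lower number from compound 3 to compound 4 (0.77 log units; beyond the scatter) swaps both the group and its place on the ring, and it rests on compound 3, whose value is a limit and not a number: the limit of > 100000 nM in this assay, at which 1 of the 4 values shown sits.

What the compounds shown leave open is whether the gain belongs to the nitro group itself or to its place on the ring, as each of the two substituents appears at one ring position only. A chlorine atom, a methoxy group or an amine at the same carbon, or a nitro group elsewhere on the ring, would begin to separate these two readings.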